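Benzyl in Place of Chlorophenyl on the Triazole Nitrogen

The compounds below may be only part of what the source reports. "The series", "measured", "known", "first", "only" and "open" are said of these compounds alone.

Compound 2 `O=c1nc2oc(C3CC3)cc2cn1Cc1cn(-c2ccc(Cl)cc2)nn1` carries a 4-chlorophenyl group on an aromatic nitrogen. In a functional assay on CFPAC-1 cells (Homo sapiens) for antiproliferative activity, read by MTT assay, with a stated time of 72 h (a lower number here means a stronger inhibitor, a higher number a weaker inhibitor), compound 2 gives only a limit, > 100000 nM, not a number. That limit is the one described in the limit of > 100000 nM in this assay, at which 1 of the 2 values shown sits. Compound 1 `O=c1nc2oc(C3CC3)c(C#CC3CC3)c2cn1Cc1cn(Cc2ccccc2)nn1`, bearing a benzyl group on that nitrogen and an additional alkyne substituent on the shared core, gives 4590 nM in this assay. Compound 3 `O=c1nc2oc(C3CC3)cc2cn1Cc1cn(Cc2ccccc2)nn1` differs from compound 2 by benzyl in place of 4-chlorophenyl on an aromatic nitrogen. Among the compounds with values here, no measured step covers this change; a gain beyond the scatter is expected, though its size is uncertain. For compound 3 a value of 30000 nM is estimated, within 8000 nM to 100000 nM. The expected step is an at least 3.3-fold lower number from compound 2 to compound 3 (0.52 log units; beyond the scatter).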

Compound 3, half-maximal inhibitory concentration: 48500 nM
Estimate against measurement, compound 3: 1.6-fold (0.21 log units) below; measured number inside the range.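

Benzyl in place of 4-chlorophenyl on the aromatic nitrogen brings a readable number in this assay, with an at least 2.0-fold lower number from compound 2 to compound 3 (0.31 log units; beyond the scatter). Going by these compounds, the value of compound 2 is a limit and not a number, so the true size of that step stays open: the limit of > 100000 nM in this assay, at which 1 of the 3 values shown sits. Benzyl alone does not account for the activity of compound 1: hydrogen in place of 2-cyclopropylethynyl on an aromatic carbon gives an 11-fold higher number from compound 1 to compound 3 (1.02 log units; beyond the scatter). The compounds shown leave open how 4-chlorobenzyl or phenethyl on that nitrogen would read, and whether 2-cyclopropylethynyl would give a measurable number alongside 4-chlorophenyl.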